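Chloro added to the phenyl of compound 2

The source may hold more compounds than are shown below. What is called first, only, known or untested is meant among the compounds shown, and "the series" means these compounds.

Going by the values given here, compound 2 `Cc1cccc(Nc2nc(C)c(C(=O)/C=C/c3ccccc3)s2)c1` is the only member of the pair with a numeric result: in a functional assay on NCI-H460 cells (Homo sapiens) for cytotoxicity, read by MTT assay (a lower number here means a stronger inhibitor, a higher number a weaker inhibitor), compound 2 gives 21800 nM. Compound 1 `Cc1nc(Nc2cccc(Cl)c2)sc1C(=O)/C=C/c1ccc(Cl)cc1` returns a limit rather than a number, > 25000 nM, consistent with the limit of > 25000 nM in this assay, at which 1 of the 2 values shown sits. The two differ at both aryl ends, so their values are noted side by side without drawing a step from them.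

Compound 3 `Cc1cccc(Nc2nc(C)c(C(=O)/C=C/c3ccc(Cl)cc3)s2)c1` is the unmeasured analogue of compound 2 with chloro in place of hydrogen on an aromatic carbon, that is phenyl to 4-chlorophenyl, the entering group sitting on an aromatic carbon of a six-membered aromatic ring of carbon only, para to a large group. Among the compounds with values here, no measured step isolates this change. Compound 1 carries the same 4-chlorophenyl and returns only a limit in this assay. Since compound 2 already gives a weak result with 21800 nM, the step is expected to be small, none beyond the scatter or a drift toward weaker inhibition, taken as a 1.2-fold higher number from compound 2 to compound 3 (0.08 log units; within the scatter). The estimate for compound 3 in this assay is 26000 nM, within 12000 nM to 60000 nM, with a fair chance that only a limit is reported.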

Compound 3, half-maximal inhibitory concentration: > 25000 nM
Compound 3: only a limit was reported (the forecaster's own chance of this, stated with the estimate: 50%); the middle value lies beyond the limit too.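

In this assay compound 3 gives > 25000 nM, which is a limit and not a number. As far as these compounds go, this gives the series its first readable step for chloro in place of hydrogen at this position, on an aromatic carbon of a six-membered aromatic ring of carbon only, para to a large group: the change gives an at least 1.1-fold higher number from compound 2 to compound 3 (0.05 log units; that floor lies within the scatter), so no gain in inhibition appears and the true size of the step stays unknown, while the step for methyl in place of chloro on an aromatic carbon cannot be read, since both of its compounds return only limits. The series now reads mostly as results at the edge of the measurable range, so further changes that push in this direction may yield little beyond another limit: the limit of > 25000 nM in this assay, at which 2 of the 3 values shown sit.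

With compound 2 as the only numeric anchor, the data do not show how far the 4-chlorophenyl change reaches past its floor, or whether the methyl and chloro on the other aryl end differ at all. Also open, from the compounds shown here alone, is what a methoxy group, a fluoro or an amine at the same position would do, and in particular whether any group there can bring the number down.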